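Removing the aryl group entirely from the shared core

A few compounds are considered here, and "the series" means these few. Any claim that something is new, unique, unknown or untested is made for them only; others in the source may bear on it.

Of the compounds shown here, three built on one core have been measured in a functional assay on Jurkat cells for inhibition of Apoptosis regulator Bcl-2 (Homo sapiens); a higher number here means a weaker inhibitor of growth, a lower number a stronger inhibitor of growth. Compound 1 `CCOC(=O)C1=C(N)Oc2ccc(-c3ccccc3)cc2C1C(C#N)C(=O)OCC` gives 4200 nM. Compound 2 `CCOC(=O)C1=C(N)Oc2ccc(-c3ccc(C(C)(C)C)cc3)cc2C1C(C#N)C(=O)OCC` gives 990 nM, and compound 3 `CCOC(=O)C1=C(N)Oc2ccc(C)cc2C1C(C#N)C(=O)OCC` gives 37000 nM. Compound 2 thus holds the lowest number of the three: the measured step is a 4.2-fold lower number from compound 1 to compound 2 (0.63 log units; beyond the scatter), and the next is a 37-fold higher number from compound 2 to compound 3 (1.57 log units; beyond the scatter). Compound 1 and compound 3 are separated by an 8.8-fold higher number from compound 1 to compound 3 (0.94 log units; beyond the scatter).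

Compound 4 `CCOC(=O)C1=C(N)Oc2ccccc2C1C(C#N)C(=O)OCC` is not yet measured. It differs from compound 2 by hydrogen in place of 4-(tert-butyl)phenyl on an aromatic carbon. Among the measured compounds shown here, two measured steps bear on this. The loss of the whole 4-(tert-butyl)phenyl for a methyl gave a 37-fold higher number from compound 2 to compound 3 (1.57 log units; beyond the scatter), and the loss of phenyl for a methyl gave an 8.8-fold higher number from compound 1 to compound 3 (0.94 log units; beyond the scatter). Compound 4 keeps not even the methyl, so a large rise in this assay is expected, at least of the size seen for compound 3, giving an expected step of a 51-fold higher number from compound 2 to compound 4 (1.70 log units; beyond the scatter). Compound 4 is therefore estimated at 50000 nM, with a range from 15000 nM to 160000 nM.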

Compound 4, concentration for 50% growth inhibition: 94000 nM
For compound 4 the middle estimate is 1.9-fold (0.27 log units) below the measured one; low and high end bracket the measured number.
By their numbers in this assay, from the lowest: compound 2; then compound 1; then compound 3; then compound 4.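

Hydrogen now gives a bare reference point at this aromatic carbon, and in this assay even the small methyl counts for something there, since removing it gives a 2.5-fold higher number from compound 3 to compound 4 (0.40 log units; beyond the scatter). Among the compounds shown here, measured against the same hydrogen, the two aryl groups span a much wider range, with a 22-fold higher number from compound 1 to compound 4 (1.35 log units; beyond the scatter) and a 95-fold higher number from compound 2 to compound 4 (1.98 log units; beyond the scatter), so across these four compounds the number falls at each step from hydrogen through methyl and phenyl to 4-(tert-butyl)phenyl, and no compound goes against that order. The data at hand offer no independent information that would explain this order.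

The compounds shown leave open whether an aromatic ring is needed at this position at all, or whether a plain hexyl chain could take the place of phenyl. They also leave open whether an amine or a carboxylic acid in place of the tert-butyl group would preserve the low number of compound 2 990 nM.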